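This account rests on a few compounds, and the source may have more. Where it says the series, first, only, none or still open, it means among the compounds named here.

Measured compounds:
- compound 1, `CCOC(=O)[C@H](CCC(=O)O)NC(=O)c1ccc(CNc2nc3cc(N)cc(N)c3nc2-c2ccccc2)cc1`: in a functional assay on M14 cells (Homo sapiens) for inhibition, read by sulforhodamine B assay, with a stated time of 48 h (on this read-out lower numbers stand for stronger inhibition of growth and higher numbers for weaker inhibition of growth), compound 1 gives < 100000 nM, a limit of the assay rather than a number.
- compound 2, `Nc1cc(N)c2nc(-c3ccccc3)c(NCc3ccc(Cl)c(Cl)c3)nc2c1`: in this assay compound 2 gives 34700 nM.
- compound 3, `COc1ccc(Sc2nc3cc(N)cc(N)c3nc2-c2ccccc2)cc1`: in this assay compound 3 gives < 100000 nM, again a limit and not a number.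

Compound 3 therefore has no numerical place among the values shown; it sits at the limit of < 100000 nM in this assay, at which 2 of the 3 values shown sit, and only compound 2 carries a measured number. Among the measured compounds shown here, no step between measured compounds that differ in one place is available, so nothing itself sets the scale of a single substituent change.

Compound 4, `Nc1cc(N)c2nc(-c3ccccc3)c(Sc3ccc(F)cc3)nc2c1`, differs from compound 3 by fluoro in place of methoxy on an aromatic carbon. For compound 4 in this assay, the step from compound 3 is expected to be a step that the limit leaves unreadable from compound 3 to compound 4, which is to say no step beyond the scatter, since compound 3 offers only a limit as the starting point. The estimate for compound 4 is 60000 nM, with a range from 20000 nM to 100000 nM, and a real chance that the assay again reports only a limit.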

Compound 4, concentration for total growth inhibition: 30900 nM
Compound 4: middle estimate off by 1.9-fold (0.29 log units), on the high side; the range from low to high includes it.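

No step can be read from compound 3 to compound 4, fluoro in place of methoxy, because the value of compound 3 is a limit of the assay and not a number: the limit of < 100000 nM in this assay, at which 2 of the 4 values shown sit. How far any single change in one place moves growth inhibition in this assay remains open among the compounds shown.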